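Propoxy in place of propyl on the shared core

The source may hold more compounds than are shown below. What is called first, only, known or untested is meant among the compounds shown, and "the series" means these compounds.

Measured so far in a functional assay (spleen, spleen) for activation, with Mus musculus as the target; on this read-out lower numbers stand for an effect already at smaller amounts and higher numbers for an effect only at larger amounts of compound:
compound 1 `CCNc1nc(N)c2nc(O)n(Cc3ccccc3)c2n1`: 1 uM
compound 2 `CCCNc1nc(N)c2nc(O)n(Cc3ccccc3)c2n1`: 0.1 uM
compound 3 `CCCc1nc(N)c2nc(O)n(Cc3ccccc3)c2n1`: 1 uM

Compound 3 stands level with compound 1 at the digits shown, and the two together carry the highest numbers of the three. Its nearest neighbour is shown by no change at the digits printed from compound 1 to compound 3 (within the scatter); its furthest by a 10-fold higher number from compound 2 to compound 3 (1.00 log units; beyond the scatter). Only compound 2 is separated from it beyond the scatter.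

Compound 4 `CCCOc1nc(N)c2nc(O)n(Cc3ccccc3)c2n1` differs from compound 3 in one place: propoxy in place of propyl on an aromatic carbon.

Among the compounds with values here, two measured steps touch the same aromatic carbon. In the step of a 10-fold higher number from compound 2 to compound 3 (1.00 log units; beyond the scatter) a propylamino group stood against the bare propyl; in the step of no change at the digits printed from compound 1 to compound 3 (within the scatter) an ethylamino group stood against it. A chain carried through a nitrogen thus gave either no change or a modestly lower number than the bare chain. Within the data shown here, no compound with an oxygen-linked chain has been measured, so the propoxy group has no direct precedent.

The expectation for compound 4 is a modestly lower number than compound 3, short of compound 2, an estimated step of a 3.3-fold lower number from compound 3 to compound 4 (0.52 log units; beyond the scatter). Compound 4 is estimated at 0.3 uM, with a range from 0.1 uM to 1 uM.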

Compound 4, minimum effective concentration: 0.01 uM
Compound 4: middle estimate off by 30-fold (1.48 log units), on the high side; the whole stated range lies above it.
By their numbers in this assay, from the lowest: compound 4; then compound 2; then compounds 1 and 3 (each within the scatter of the next).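

In this assay, within the data shown here, the atom linking the chain to this aromatic carbon between two ring nitrogen atoms carries more weight than the earlier compounds showed: propoxy in place of propyl gives a 100-fold lower number from compound 3 to compound 4 (2.00 log units; beyond the scatter), and propoxy in place of propylamino gives a 10-fold lower number from compound 2 to compound 4 (1.00 log units; beyond the scatter). Propoxy in place of ethylamino gives a 100-fold lower number from compound 1 to compound 4 (2.00 log units; beyond the scatter), although that step changes both the link and the chain, so it does not isolate the effect of the oxygen. Among the three-carbon chains the numbers fall from propyl through propylamino to propoxy, but compound 1 goes against any simple rule that a nitrogen link beats a bare chain, since compound 1 stands level with compound 3 at the digits printed, and no supporting measurement bears on the reason for this order.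

As far as these compounds go, the chain length on oxygen remains open, and ethoxy and butoxy would show whether it matters as it does on nitrogen, where the step is a 10-fold lower number from compound 1 to compound 2 (1.00 log units; beyond the scatter). A propylthio group would show whether the low number extends to a sulfur link.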